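The source may hold more compounds than are shown below. What is called first, only, known or untested is meant among the compounds shown, and "the series" means these compounds.

Among the compounds with values here, in a functional assay on NCI-H630 cells (Homo sapiens) for cytotoxicity, read by sulforhodamine B assay, with a stated time of 5 days (on this read-out higher numbers stand for weaker inhibition and lower numbers for stronger inhibition), compound 1 `O=C(CCCCCCCCCCCc1ccccc1)CC(=O)N[C@H]1CCOC1=O` gives 27000 nM, the only actual number among the three compounds measured so far. Compound 2 `O=C(CCCc1ccccc1)N[C@H]1CCOC1=O` gives > 100000 nM, which is a limit of the assay and not a number. Compound 3 `O=C(CCCCCCCCc1ccccc1)N[C@H]1CCOC1=O` gives > 100000 nM, which is also a limit. Compound 1 therefore has a number, while compound 2 and compound 3 have none to rank against it.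

The next compound, compound 4 `O=C(CCCCCCCCc1ccccc1)CC(=O)N[C@H]1CCOC1=O`, keeps the core of compound 1 and changes the far end of the chain: phenyl in place of 3-phenylpropyl on a saturated chain carbon, eight bonds along the chain from a carbonyl carbon. In words, this is phenyl in place of 3-phenylpropyl on a saturated chain carbon, eight bonds along the chain from a carbonyl carbon.

Within the data shown here, no measured pair shows this change on its own. A modest step toward weaker inhibition is expected in this assay, because of the limit of > 100000 nM in this assay, at which 2 of the 3 values shown sit. The expected change is a 2.2-fold higher number from compound 1 to compound 4 (0.35 log units; beyond the scatter). For compound 4, the estimated value is 60000 nM, with an expected range of 25000 nM to 100000 nM.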

Compound 4, half-maximal inhibitory concentration: 10000 nM
Estimate against measurement, compound 4: 6.0-fold (0.78 log units) above; measured number below the stated range.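

In this assay, the step from 3-phenylpropyl to phenyl on a saturated chain carbon, eight bonds along the chain from a carbonyl carbon, gives a 2.7-fold lower number from compound 1 to compound 4 (0.43 log units; beyond the scatter), and a lower number here means stronger inhibition. Within the data shown here, this is the first step that can be read. Compound 1 no longer stands alone with an actual number. It shows that the longer chain end of compound 1 is not needed for activity, and that removing those three chain carbons strengthens inhibition rather than weakens it.

Going by these compounds, one step cannot show whether a still shorter or a longer chain would continue this direction, and few actual numbers are available to test it: the limit of > 100000 nM in this assay, at which 2 of the 4 values shown sit. Also open is what an amine or a carboxylic acid would do in place of the phenyl at this chain end.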